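The source may hold more compounds than are shown below. What is called first, only, known or untested is meant among the compounds shown, and "the series" means these compounds.

Compound 1 `O=S(=O)(Nc1ccc2oc(-c3ccccc3)nc2c1)c1ccc(Cl)c(Cl)c1` sits at a limit of an assay on isolated protein for inhibition of malate dehydrogenase, mitochondrial (Sus scrofa), with stated times of 45 min and 30 min (on this read-out lower numbers stand for stronger inhibition and higher numbers for weaker inhibition), > 63000 nM.
Compound 2 `O=S(=O)(Nc1ccc(-c2nc3ccccc3o2)cc1)c1ccccc1C(F)(F)F` sits at a limit of this assay, > 63000 nM.
Compound 3 `O=S(=O)(Nc1ccc(-c2nc3ccccc3o2)cc1)c1ccccc1O` sits at a limit of this assay, > 63000 nM.

Compound 3 therefore stands at the assay limit, which is not a number, and so do both other compounds: the limit of > 63000 nM in this assay, at which 3 of the 3 values shown sit. For the measured compounds named here, the one step between measured compounds, a step that the two limits leave unreadable from compound 2 to compound 3, cannot be sized for that reason. Compound 4 `O=S(=O)(Nc1ccc(-c2nc3ccccc3o2)cc1)c1ccc(Cl)s1` differs from compound 3 by 5-chlorothiophen-2-yl in place of 2-hydroxyphenyl on a sulfonyl sulfur. No readable step bears on this change, so there is no basis for expecting a shift in either direction beyond the scatter; the expected step is a step that the limit leaves unreadable from compound 3 to compound 4. Compound 4 is thus estimated at 80000 nM, with a range from 20000 nM to 300000 nM, most probably reported again only as a limit.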

Compound 4, half-maximal inhibitory concentration: > 63000 nM
Compound 4 ended at the assay's limit; the forecaster's own chance of this, stated with the estimate: 85%; the middle value is on the limit's open side.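

No step can be read from compound 3 to compound 4, since both values are limits and not numbers: the limit of > 63000 nM in this assay, at which 4 of the 4 values shown sit.

The compounds shown leave open what change to this series would give a readable value in this assay.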